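The compounds below may be only part of what the source reports. "The series", "measured", "known", "first", "only" and "open" are said of these compounds alone.

Notes on the ester series in a functional assay on K562 cells (Homo sapiens) for antiproliferative activity, read by sulforhodamine B assay, with a stated time of 48 h, tested at 50 uM; on this read-out lower numbers stand for less inhibition and higher numbers for more inhibition at the one concentration tested (going by the name of the read-out). Compound 1 `COc1cccc(C(=O)Oc2cc3c(cc2C)[C@@H](C(C)C)CC=C3C)c1` is recorded in this assay as "not active" (no number reported), so no single number stands for compound 1 on this read-out; it gives no measurable inhibition at the one concentration tested. Compound 2 `COc1cccc(C(=O)Oc2cc3c(C)ccc(C(C)C)c3cc2C)c1`, which carries the same ester on a different core, gives in this assay a read-out of 14.2%, a small inhibition. Going by the values given here, no step between two measured compounds is available, so the scatter of this read-out is the only yardstick for judging any change. Compound 3 `CC1=CC[C@H](C(C)C)c2cc(C)c(OC(=O)c3cccc(Cl)c3)cc21` keeps the core of compound 1 and differs from it in one place: chloro in place of methoxy on an aromatic carbon. With compound 1 standing at "not active" (no number reported), the change from compound 1 to compound 3 is expected to move the read-out in this assay by no more than the usual scatter, if at all, in either direction; a slight rise cannot be excluded, but nothing in the series supports a large one. For compound 3 the inhibition in this assay is estimated at 10%, with a range from 0% to 28%, and a fair chance that only "not active" is reported again.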

Compound 3, a percentage reported as inhibition, at one concentration (the size of the read-out at that concentration, not a potency): "not active" (no number reported)
Nothing numeric was reported for compound 3; there is nothing to compare the estimate with.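

In this assay compound 1 gives "not active" (no number reported) and compound 3 gives "not active" (no number reported), so no step can be read from the change of 3-methoxyphenyl to 3-chlorophenyl. No measured evidence bears on this result. The compounds shown leave open whether any ester on the core of compound 1 gives measurable inhibition.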